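Removing the methoxy group: from compound 3 to compound 4

A few compounds are considered here, and "the series" means these few. Any claim that something is new, unique, unknown or untested is made for them only; others in the source may bear on it.

Measured so far:
- compound 1, `CCC1(CCCCN2CCN(c3ccc(Cl)cc3)CC2)C(=O)Nc2ccccc21`: 10 mg/kg
- compound 2, `CCC1(CCCCN2CCN(c3cccc(OC)c3)CC2)C(=O)Nc2ccccc21`: > 20 mg/kg (a limit of the assay, not a number)
- compound 3, `CCC1(CCCCN2CCN(c3ccccc3OC)CC2)C(=O)Nc2ccccc21`: 10 mg/kg

In a functional assay on the whole organism (strain Wistar) with Rattus norvegicus as the target, with a stated time of 5 min (a lower number here means that less compound is needed, a higher number that more compound is needed for the effect), compound 3 gives 10 mg/kg. Compound 3 stands level with compound 1, which in this assay gives 10 mg/kg, so that no change at the digits printed from compound 1 to compound 3 (within the scatter). Compound 2 gives only a limit in this assay, > 20 mg/kg. The step of an at least 2.0-fold lower number from compound 2 to compound 3 (0.30 log units; that floor lies within the scatter) rests on that limit (the limit of > 20 mg/kg in this assay, at which 1 of the 3 values shown sits), and so does an at least 2.0-fold higher number from compound 1 to compound 2 (0.30 log units; that floor lies within the scatter).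

Compound 4, `CCC1(CCCCN2CCN(c3ccccc3)CC2)C(=O)Nc2ccccc21`, is not yet measured. It differs from compound 3 in one place: hydrogen in place of methoxy on an aromatic carbon. For the measured compounds named here, none of the measured steps removes a group outright: each swaps one substituted phenyl for another. Two of the three measured compounds sit at the same value, and only compound 2 departs, and that only as a limit. Since the measured steps do not touch an unsubstituted phenyl, the expectation for compound 4 is at best a rough one, with room for a somewhat higher number.

Compound 4 is therefore expected to give about 15 mg/kg, between 7 mg/kg and 30 mg/kg. This estimate means a step of a 1.5-fold higher number from compound 3 to compound 4 (0.18 log units; within the scatter), which is expected to stay within the scatter.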

Compound 4, minimum effective dose: 10 mg/kg
The estimate for compound 4 lay 1.5-fold (0.18 log units) above the measured number; the range from low to high includes it.
By their numbers in this assay, from the lowest: compounds 1, 3 and 4 (each within the scatter of the next). At a limit, above all of these: compound 2.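

In this assay, removing the methoxy group leaves no change at the digits printed from compound 3 to compound 4 (within the scatter), and removing the chloro group leaves no change at the digits printed from compound 1 to compound 4 (within the scatter). Among these compounds, then, the plain phenyl does as well as the 2-methoxyphenyl and 4-chlorophenyl groups, so neither substituent is needed to reach this dose. The 3-methoxyphenyl group alone may stand apart, yet the plain phenyl gives an at least 2.0-fold lower number from compound 2 to compound 4 (0.30 log units; that floor lies within the scatter), and this step rests on a limit of the assay, not a number: the limit of > 20 mg/kg in this assay, at which 1 of the 4 values shown sits.

Still open, from the compounds shown here alone, is whether any group on this ring could bring the dose needed clearly down, for example an amine, a carboxylic acid or a trifluoromethyl group. Also open, going by these compounds, is whether a longer chain between the core and the ring-bearing amine would change the dose at all.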